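Working notes: from compound 2 to compound 4

A few compounds are considered here, and "the series" means these few. Any claim that something is new, unique, unknown or untested is made for them only; others in the source may bear on it.

In a functional assay on HepG2 cells (Homo sapiens) for cytotoxicity, read by MTT assay, with a stated time of 72 h (a lower number here means a stronger inhibitor, a higher number a weaker inhibitor), compound 2 `COc1ccc(/C=N/NC(=O)Nc2cc3c(Nc4ccc(F)c(Cl)c4)ncnc3cc2O[C@H]2CCOC2)c(OC)c1OC` gives 29300 nM. Compound 1 `COc1ccc(/C=N/NC(=O)Nc2cc3c(Nc4ccc(F)c(Cl)c4)ncnc3cc2O[C@H]2CCOC2)cc1` gives 28800 nM, which lies within the scatter of compound 2. Compound 3 `CC(C)(C)c1cc(/C=N/NC(=O)Nc2cc3c(Nc4ccc(F)c(Cl)c4)ncnc3cc2O[C@H]2CCOC2)cc(C(C)(C)C)c1O` gives a lower number than both, 12500 nM.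

Compound 4 `O=C(N/N=C/c1ccc(O)cc1)Nc1cc2c(Nc3ccc(F)c(Cl)c3)ncnc2cc1O[C@H]1CCOC1` carries 4-hydroxyphenyl in place of 2,3,4-trimethoxyphenyl on a carbon with a double bond to nitrogen.

Among the measured compounds shown here, only one measured step bears directly on this place: a 1.0-fold higher number from compound 1 to compound 2 (0.01 log units; within the scatter), with 2,3,4-trimethoxyphenyl in place of 4-methoxyphenyl, and it stays within the scatter. For the measured compounds named here, no measured step connects compound 3 to the other two through a change in one place, so its value gives only loose guidance, and no measured step introduces 4-hydroxyphenyl. A change beyond the scatter is therefore not expected in this assay. The expected step is a 1.2-fold lower number from compound 2 to compound 4 (0.07 log units; within the scatter), which stays within the scatter. Compound 4 is estimated at 25000 nM, with an expected range from 12000 nM to 50000 nM.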

Compound 4, half-maximal inhibitory concentration: 70 nM
Compound 4: the middle estimate sits 360-fold (2.55 log units) above what was measured; the measured number lies below the stated range.
By their numbers in this assay, from the lowest: compound 4; then compound 3; then compounds 1 and 2 (each within the scatter of the next).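

In this assay, the place on a carbon with a double bond to nitrogen looked flat across compounds 1 and 2, but it proves highly sensitive: 4-hydroxyphenyl in place of 2,3,4-trimethoxyphenyl gives a 420-fold lower number from compound 2 to compound 4 (2.62 log units; beyond the scatter). The closer comparison narrows the change to hydrogen in place of methyl on an oxygen on an aromatic ring, which alone gives a 410-fold lower number from compound 1 to compound 4 (2.61 log units; beyond the scatter), so the group need not lose its ring or gain bulk for the number to fall this far. Nothing on hand accounts for a step of this size.

Compound 3 also holds a hydroxy group on its ring, together with two tert-butyl groups, yet gives 12500 nM, so a hydroxy group alone does not settle the outcome. From the compounds shown here alone, whether an amine or a carboxylic acid in place of that hydroxy group would keep the low number remains open.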